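Taking the Amino Group off Compound 2

The compounds below may be only part of what the source reports. "The series", "measured", "known", "first", "only" and "open" are said of these compounds alone.

Measured so far:
Compound 1, `COc1cc2c(cc1OC)C(c1ccc([N+](=O)[O-])cc1)=NNC(=O)C2`: > 150 umol/kg
Compound 2, `COc1cc2c(cc1OC)C(c1ccc(N)cc1)=NN(C)C(=S)C2`: 130 umol/kg
Compound 3, `COc1cc2c(cc1OC)C(c1ccc(Br)cc1)=NN=C(S)C2`: 73 umol/kg

Of the compounds shown here, three sharing one core have been tested in a functional assay on the whole organism with Mus musculus as the target, in the rotarod test; on this read-out higher numbers stand for an effect only at larger amounts of compound and lower numbers for an effect already at smaller amounts. For compound 1 the result is only a limit of the assay, (the limit of > 150 umol/kg in this assay, at which 1 of the 3 values shown sits), not a number. Compound 2 and compound 3 both give numbers, and these two lie within the usual scatter of each other, so nothing separates them. Compound 2 thus stands among two comparable numbers, with one further value that is a limit.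

Compound 4, `COc1cc2c(cc1OC)C(c1ccccc1)=NN(C)C(=S)C2`, has not yet been measured in this assay. It differs from compound 2 in one place: hydrogen in place of amino on an aromatic carbon. The change is small in size, and only the two numbers of compound 2 and compound 3, together with the limit of compound 1, give any footing for what to expect. On that footing no step beyond the scatter is expected from compound 2 to compound 4, and the estimated step is a 1.2-fold lower number from compound 2 to compound 4 (0.07 log units; within the scatter). Compound 4 is expected to give about 110 umol/kg in this assay, with a plausible range from 50 umol/kg to 250 umol/kg.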

Compound 4, dose for half-maximal effect: 97.1 umol/kg
Estimate against measurement, compound 4: 1.1-fold (0.05 log units) above; the range from low to high includes it.
By their numbers in this assay, from the lowest: compounds 3, 4 and 2 (each within the scatter of the next). At a limit, above all of these: compound 1.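

For the compounds shown here, compound 2 and compound 4 are the first pair here that differ in one place only, so the change from 4-aminophenyl to phenyl can be read directly in this assay, as a 1.3-fold lower number from compound 2 to compound 4 (0.13 log units; within the scatter). The earlier compounds shown here could not show this, since compound 1 and compound 3 each differ from compound 2 in more than one place; the pair now shows that, on this aromatic carbon para to a large group, amino and hydrogen cannot be told apart on this read-out. Nothing among the data shown gives a reason for this outcome.

Going by these compounds, what a group other than amino or hydrogen would do at this same position, such as a methoxy group, a carboxylic acid or a longer chain like butyl, stays open, and the steps from compound 1 and compound 3 to the other compounds cannot be read, so the bromo and nitro groups they carry give no answer. Compound 1 stands at a limit of the assay, > 150 umol/kg, which is not a number.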